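Ethyl for methyl on the amine, second core

A few compounds are considered here, and "the series" means these few. Any claim that something is new, unique, unknown or untested is made for them only; others in the source may bear on it.

Measured compounds:
compound 1 `CNCC(=O)Nc1cc(OC)ccc1C(=O)c1ccc(OC)c2c1C=CC(C)(C)O2` — 1370 nM
compound 2 `CNCC(=O)Nc1cc(OC)ccc1C(=O)c1ccc2c(c1)C=CC(C)(C)O2` — 800 nM
compound 3 `CCNCC(=O)Nc1cc(OC)ccc1C(=O)c1ccc(OC)c2c1C=CC(C)(C)O2` — 2310 nM

The three compounds were tested in a functional assay on A549 cells (Homo sapiens) for antiproliferative activity, read by MTT assay, with a stated time of 48 h; on this read-out lower numbers stand for stronger inhibition and higher numbers for weaker inhibition. Compound 1 gives 1370 nM and compound 3 gives 2310 nM; the change between them is methyl in place of hydrogen on a saturated chain carbon bound to an amine nitrogen, and the step it made is a 1.7-fold higher number from compound 1 to compound 3 (0.23 log units; within the scatter). Compound 2 gives 800 nM; the difference between the core of compound 1 and the core of compound 2 is not broken down here, so compound 2 and compound 1 are compared only by their two values, which sit within the scatter of each other.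

Compound 4 `CCNCC(=O)Nc1cc(OC)ccc1C(=O)c1ccc2c(c1)C=CC(C)(C)O2` is not yet measured in this assay. It differs from compound 2 by methyl in place of hydrogen on a saturated chain carbon bound to an amine nitrogen, the same change as that from compound 1 to compound 3, at the same place in both words. For the measured compounds named here, only one measured instance of this change exists, so the expectation rests on a single step. The step from compound 2 to compound 4 is expected to be a 1.6-fold higher number from compound 2 to compound 4 (0.21 log units; within the scatter), alongside a 1.7-fold higher number from compound 1 to compound 3 (0.23 log units; within the scatter), on the assumption that the change reads the same on the core of compound 2 as on the core of compound 1. On that basis compound 4 is estimated at 1300 nM, with a likely range from 650 nM to 2800 nM.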

Compound 4, half-maximal inhibitory concentration: 1300 nM
For compound 4 middle estimate and measured number coincide at the digits printed; measured number inside the range.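

In this assay, the change from methyl to ethyl on the amine gives a 1.6-fold higher number from compound 2 to compound 4 (0.21 log units; within the scatter), and it reads on the core of compound 2 much as on the core of compound 1: the same change on two cores in this assay, a 1.7-fold higher number (0.23 log units; within the scatter) from compound 1 to compound 3 and a 1.6-fold higher number (0.21 log units; within the scatter) from compound 2 to compound 4, 1.0-fold (0.02 log units) apart, within the scatter of two such steps

Both steps lie within the scatter, so what carries from one core to the other is the lack of a resolved shift: the change does not separate from repeat measurement on either core, and the data do not establish that ethyl gives weaker inhibition than methyl in this series. The agreement rests on one pair of steps in a single cell assay, so it says nothing about further cores, other cell lines or any larger change at this place, and a small core dependence hidden inside the scatter cannot be excluded.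

Open, from the compounds shown here alone, is how the read-out responds to a larger departure from methylamino at the same place, such as a longer chain like propylamino, a branched isopropylamino group, a cyclic amine like pyrrolidine or a free primary amine. Any of these could show whether a step beyond the scatter exists here, and whether such a step would also carry from one core to the other.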